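Ester of a Trifluoromethylated Benzoic Acid Replaces a Benzyl Ether

This account rests on a few compounds, and the source may have more. Where it says the series, first, only, none or still open, it means among the compounds named here.

In a functional assay on MDA-MB-231 cells (Homo sapiens) for antiproliferative activity, read by MTT assay, with a stated time of 72 h (a lower number here means a stronger inhibitor, a higher number a weaker inhibitor), compound 1 `CC1=CC[C@H]2[C@@H]1CC=C(C)[C@@H](CCC1=C(C)CC[C@@H]3OC(C)(C)[C@@H](O)CC[C@@]13C)C2(C)C` returns only a limit, > 50000 nM (the limit of > 50000 nM in this assay, at which 1 of the 3 values shown sits). Compound 2 `CC1=CC[C@H]2[C@H](CC[C@]2(C)O)C(C)(C)[C@@H]1CC[C@H]1[C@]2(C)CC[C@H](OCc3ccccc3)C(C)(C)O[C@H]2CC[C@@]1(C)O` gives 29100 nM in this assay, the lower of the two plain numbers recorded, while compound 3 `CC1=CC[C@H]2[C@H](CC[C@]2(C)O)C(C)(C)[C@@H]1CC[C@H]1[C@]2(C)CC/C(=N/OCc3ccccc3)C(C)(C)O[C@H]2CC[C@@]1(C)O` gives 38200 nM, a value within the scatter of compound 2. Compound 4 `CC1=CC[C@H]2[C@H](CC[C@]2(C)O)C(C)(C)[C@@H]1CC[C@H]1[C@]2(C)CC[C@H](OC(=O)c3cccc(C(F)(F)F)c3)C(C)(C)O[C@H]2CC[C@@]1(C)O` has not yet been measured in this assay. It differs from compound 2 in a single place: (3-(trifluoromethyl)phenyl)carbonyl in place of benzyl on an oxygen on a saturated carbon. Going by the values given here, no step between measured compounds has been recorded, so the size of this change cannot be read from a precedent; the expected shift in this assay is none beyond the scatter. Compound 4 is therefore expected to give about 25000 nM, in a range from 8000 nM to 80000 nM. The expected step of a 1.2-fold lower number from compound 2 to compound 4 (0.07 log units; within the scatter) stays within the usual scatter.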

Compound 4, half-maximal inhibitory concentration: 36300 nM
Compound 4: the middle estimate sits 1.5-fold (0.16 log units) below what was measured; measured number inside the range.
By their numbers in this assay, from the lowest: compounds 2, 4 and 3 (each within the scatter of the next). At a limit, above all of these: compound 1.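

In this assay, the step at this position is a 1.2-fold higher number from compound 2 to compound 4 (0.10 log units; within the scatter). Going by these compounds alone, this is the first change read at this oxygen on a saturated carbon, and it shows that the benzyl ether can give way to the (3-(trifluoromethyl)phenyl)carbonyl ester, with its added carbonyl and larger group, without moving the number beyond the scatter. Nothing measured here offers a reason for this result. The compounds shown leave open how an unsubstituted benzoyl ester would compare, which would separate the carbonyl from the trifluoromethyl, and whether an amine in this place would shift the number.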